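A few compounds are considered here, and "the series" means these few. Any claim that something is new, unique, unknown or untested is made for them only; others in the source may bear on it.

Compound 1 `C[C@@H](NC(=O)c1ccc(C=C2CCN(Cc3ccccc3)CC2)cc1)c1ccc(Br)cc1` gives 2580 nM in an assay on isolated protein for binding affinity to melanin-concentrating hormone receptor 1 (Homo sapiens); on this read-out lower numbers stand for stronger inhibition and higher numbers for weaker inhibition. Compound 2 `COc1ccc(CN2CCC(=Cc3ccc(C(=O)N[C@H](C)c4ccc(Br)cc4)cc3)CC2)cc1` gives 149 nM in this assay.

Compound 2 stands lowest of the two numbers; compound 1 sits above it by a 17-fold lower number from compound 1 to compound 2 (1.24 log units; beyond the scatter). Compound 3 `Cc1ccc(CN2CCC(=Cc3ccc(C(=O)N[C@H](C)c4ccc(Br)cc4)cc3)CC2)c(C)c1` is not yet measured and differs from compound 2 by 2,4-dimethylphenyl in place of 4-methoxyphenyl on a saturated chain carbon bound to an amine nitrogen in a ring. Going by the values given here, the one measured step, a 17-fold lower number from compound 1 to compound 2 (1.24 log units; beyond the scatter), came from adding a methoxy group; compound 3 loses that group and gains two methyl groups, a change no measured pair covers. A higher number is expected, so compound 3 is estimated at 450 nM, ranging from 90 nM to 2200 nM. The expected change in this assay is a 3.0-fold higher number from compound 2 to compound 3 (0.48 log units; beyond the scatter).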

Compound 3, inhibition constant: 105 nM
Beside the measured number, compound 3's estimate is 4.3-fold (0.63 log units) above it; the range from low to high includes it.
By their numbers in this assay, from the lowest: compounds 3 and 2 (each within the scatter of the next); then compound 1.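

In this assay the 4-methoxyphenyl group on this saturated chain carbon can give way to 2,4-dimethylphenyl, which has no hydrogen-bond acceptor, with a 1.4-fold lower number from compound 2 to compound 3 (0.15 log units; within the scatter) so the oxygen is not needed to hold this level. Against the plain phenyl of compound 1 the new group gives a 25-fold lower number from compound 1 to compound 3 (1.39 log units; beyond the scatter) and so keeps the large step seen with methoxy. Nothing measured on these compounds gives a reason for this.

Which of the two methyl groups carries that step stays open. So does whether a single methyl group, a chlorine atom or a hydroxyl group on this ring would serve as well.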